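A Trifluoromethyl Variant of Compound 3

The source may hold more compounds than are shown below. What is called first, only, known or untested is meant among the compounds shown, and "the series" means these compounds.

Compound 3 `O=C(N/N=C/c1ccccc1)c1cnccn1` stands second highest of the three numbers in a functional assay on the whole organism (strain Swiss) for inhibition, with Mus musculus as the target, with stated times of 40 min and 6 h, at a dose of 100 mg/kg by the oral route (on this read-out lower numbers stand for less inhibition and higher numbers for more inhibition at the one dose given (going by the name of the read-out)), where compound 3 gives 21.7%. Its nearest neighbour is compound 1 `O=C(N/N=C/c1ccc(-c2ccccc2)cc1)c1cnccn1`, for which compound 1 gives 14.4%; the furthest is compound 2 `COc1ccc(/C=N/NC(=O)c2cnccn2)cc1OC`, for which compound 2 gives 51.3%. For the measured compounds named here, one measured step bears on the present question: a number 7.3 percentage points higher from compound 1 to compound 3 (within the scatter), hydrogen in place of phenyl on an aromatic carbon. Compound 4 `O=C(N/N=C/c1ccc(C(F)(F)F)cc1)c1cnccn1` carries the change (trifluoromethyl in place of hydrogen on an aromatic carbon). Going by the values given here, since the one comparable step, a swap at that aromatic carbon, stayed within the scatter, no step beyond the scatter is expected in this assay. The estimated step is a number 3.3 percentage points higher from compound 3 to compound 4 (within the scatter). Compound 4 is therefore expected to give 25%, within 10% to 45%.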

Compound 4, a percentage reported as inhibition, in the whole organism at one dose (the size of the read-out at that dose, not a potency): 0%
Compound 4: middle estimate off by 25 percentage points, on the high side; the measured number lies below the stated range.
By their numbers in this assay, from the lowest: compound 4; then compounds 1 and 3 (each within the scatter of the next); then compound 2.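

In this assay, this aromatic carbon proves sensitive to the group it carries: trifluoromethyl in place of hydrogen gives a number 21.7 percentage points lower from compound 3 to compound 4 (beyond the scatter), whereas the earlier swap here stayed within the scatter. Trifluoromethyl and phenyl are not interchangeable at this position either, with a number 14.4 percentage points lower from compound 1 to compound 4 (beyond the scatter). Nothing shown explains this loss of inhibition. Still open, going by these compounds, is how a single fluorine, an amine or a carboxylic acid on this carbon would compare with the hydrogen of compound 3.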